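Fluoro to chloro on the shared core

A few compounds are considered here, and "the series" means these few. Any claim that something is new, unique, unknown or untested is made for them only; others in the source may bear on it.

In an ADME assay on Vero cells (Chlorocebus sabaeus) for cytotoxicity, with a stated time of 5 days (on this read-out lower numbers stand for stronger inhibition and higher numbers for weaker inhibition), compound 1 `CNc1nc(Cl)nc2c1ncn2[C@H]1C[C@H](N=[N+]=[N-])[C@@H](CO)O1` gives > 100000 nM, which is a limit of the assay. Compound 2 `CN(C)c1nc(Cl)nc2c1ncn2[C@H]1C[C@H](N=[N+]=[N-])[C@@H](CO)O1` gives > 100000 nM, also a limit. For the measured compounds named here, compound 3 `[N-]=[N+]=N[C@H]1C[C@H](n2cnc3c(N)nc(F)nc32)O[C@@H]1CO` gives 34400 nM, the only actual number so far. Compound 4 `[N-]=[N+]=N[C@H]1C[C@H](n2cnc3c(N)nc(Cl)nc32)O[C@@H]1CO` differs from compound 3 by chloro in place of fluoro on an aromatic carbon. Going by the values given here, the one measured step, a step that the two limits leave unreadable from compound 1 to compound 2, offers no size and concerns a different change. Compounds 1 and 2 both carry chloro and sit at the limit of > 100000 nM in this assay, at which 2 of the 3 values shown sit, so a modest move toward weaker inhibition is expected in this assay. The expected change is a 1.5-fold higher number from compound 3 to compound 4 (0.16 log units; within the scatter). For compound 4 the estimated value is 50000 nM, with an expected range of 15000 nM to 100000 nM.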

Compound 4, half-maximal inhibitory concentration: > 100000 nM
Compound 4 gave a limit, no number; the forecaster's own chance of this, stated with the estimate: 30%; at least 2.0-fold (0.30 log units) between middle value and limit.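

In this assay, for the compounds shown here, chloro in place of fluoro on an aromatic carbon between two ring nitrogen atoms gives the first readable step at this position: an at least 2.9-fold higher number from compound 3 to compound 4 (0.46 log units; beyond the scatter). This step is beyond the scatter, but it has only a lower bound, as the value of compound 4 is a limit. The steps among the chloro compounds cannot be read, and the series now gathers at one limit: the limit of > 100000 nM in this assay, at which 3 of the 4 values shown sit.

As far as these compounds go, it remains open whether bromo or methoxy at this carbon would give a number in this assay. From the compounds shown here alone, the effect of methylamino or dimethylamino on the fluoro compound also remains open.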